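The source may report more compounds than this note shows. Statements on the series, on what has been measured and on what is new or still open speak of the compounds shown alone.

Working notes on the series. The shared core carries a trimethoxyphenyl group and a carbamate; four members are under consideration. Compound 1 `CCCOC(=O)N1N=C(c2ccccc2)CC1c1cc(OC)c(OC)c(OC)c1`, compound 2 `COc1cc(C2CC(c3ccccc3)=NN2C(=O)OCc2ccccc2)cc(OC)c1OC` and compound 3 `CCCOC(=O)N1N=C(c2cccc(O)c2)CC1c1cc(OC)c(OC)c(OC)c1` have been run in a functional assay on HeLa cells (Homo sapiens) for antiproliferative activity, read by MTT assay, with a stated time of 48 h (a lower number here means a stronger inhibitor of growth, a higher number a weaker inhibitor of growth), while compound 4 `COc1cc(C2CC(c3cccc(O)c3)=NN2C(=O)OCc2ccccc2)cc(OC)c1OC` has not.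

In this assay compound 1 gives > 10000 nM, which is a limit of the assay and not a number. Compound 2 gives > 10000 nM, again a limit. Compound 3 gives > 10000 nM, also a limit. The change from compound 1 to compound 2 is phenyl in place of ethyl on a saturated chain carbon bound to an oxygen next to a carbonyl group, and the step that the two limits leave unreadable from compound 1 to compound 2 cannot be sized, since both values sit at the limit of > 10000 nM in this assay, at which 3 of the 3 values shown sit. The step that the two limits leave unreadable from compound 1 to compound 3, hydroxy in place of hydrogen, is equally unreadable for the same reason, both values resting at the limit of > 10000 nM in this assay, at which 3 of the 3 values shown sit.

Compound 4 stands to compound 3 as compound 2 stands to compound 1: the change is phenyl in place of ethyl on a saturated chain carbon bound to an oxygen next to a carbonyl group, the same change at the same place, this time made on the core of compound 3. The difference between the two cores is hydroxy in place of hydrogen on an aromatic carbon.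

For the measured compounds named here, with every measured member of the series sitting at the limit, nothing here points to compound 4 entering the measurable range; the step from compound 3 to compound 4 is expected to be a step that the limit leaves unreadable from compound 3 to compound 4, as unreadable as the one from compound 1 to compound 2. Compound 4 is expected to give about 15000 nM in this assay. The expected range for compound 4 runs from 7000 nM to 40000 nM, most probably reported once more as a limit.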

Compound 4, concentration for 50% growth inhibition: > 10000 nM
Compound 4: no number, only a limit; the forecaster's own chance of this, stated with the estimate: 85%; the middle value is on the limit's open side.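

In this assay compound 4 gives > 10000 nM, which is a limit of the assay and not a number. No new step can be read, neither from compound 3 to compound 4 nor from compound 2 to compound 4, with all values resting at one limit: the limit of > 10000 nM in this assay, at which 4 of the 4 values shown sit.

The compounds shown leave open the size and direction of either change, phenyl in place of ethyl or hydroxy in place of hydrogen, in this assay.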